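This account rests on a few compounds, and the source may have more. Where it says the series, first, only, none or still open, it means among the compounds named here.

Measured so far:
compound 1, `Cc1nc(-c2ccc(Cl)cc2)sc1C(=O)CSc1nc(-c2ccccc2)c(C#N)c(=O)[nH]1` — 88.9%
compound 2, `COc1ccc(-c2nc(C)c(C(=O)CSc3nc(-c4ccc(Cl)cc4)c(C#N)c(=O)[nH]3)s2)cc1` — 102%
compound 3, `COc1cccc(-c2nc(SCC(=O)c3sc(-c4ccccc4)nc3C)[nH]c(=O)c2C#N)c1` — 99%

In a functional assay on U-87MG ATCC cells for antiproliferative activity against U-87 MG (Homo sapiens), read by MTT assay, with a stated time of 48 h, tested at 5 uM (a higher number here means a weaker effect of the compound at the concentration tested, a lower number a stronger effect), compound 2 gives the highest of the three numbers. Compound 3 lies within the scatter of compound 2; compound 1 lies lower, beyond the scatter. All three numbers sit close to the untreated level, so none of the three shows a marked effect at the concentration tested.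

Compound 4, `COc1ccc(-c2nc(C)c(C(=O)CSc3nc(-c4ccc(OC)c(OC)c4)c(C#N)c(=O)[nH]3)s2)cc1`, has not been measured. It differs from compound 2 in one place: 3,4-dimethoxyphenyl in place of 4-chlorophenyl on an aromatic carbon. For the measured compounds named here, no pair with a single change has been measured, so the size of this step is unknown; with the three numbers all near the untreated level, no step beyond the scatter is expected in either direction. The step from compound 2 to compound 4 is expected to be a number 5 percentage points lower from compound 2 to compound 4 (within the scatter). Compound 4 is estimated at 97%, between 85% and 108%.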

Compound 4, a percentage reported as activity, at one concentration (the size of the read-out at that concentration, not a potency): 81.2%
For compound 4 the middle estimate is 15.8 percentage points above the measured one, and the stated range ends above it.
By their numbers in this assay, from the lowest: compounds 4 and 1 (each within the scatter of the next); then compounds 3 and 2 (each within the scatter of the next).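

Within this assay, replacing 4-chlorophenyl with 3,4-dimethoxyphenyl on the aromatic carbon ortho to a cyano group gives a step beyond the scatter: a number 20.8 percentage points lower from compound 2 to compound 4 (beyond the scatter). This position therefore responds to a change made there alone, with the number moving towards a stronger effect, although the step is modest. Nothing available accounts for this step. On these data alone, it remains open whether both methoxy groups are needed for the step, and how an amine or a carboxylic acid on that phenyl ring would read out.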